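Hydroxyamide side chain: cyclohexyl in place of cyclopropylmethyl

The source may hold more compounds than are shown below. What is called first, only, known or untested is meant among the compounds shown, and "the series" means these compounds.

Measured so far in an ADME assay on liver for metabolic stability, with Liver microsome (Homo sapiens) as the target, read by LC-MS, using microsomes; a higher number here means faster removal of the compound, a lower number slower removal:
- compound 1 `O=C(NCc1cc(Cl)ccc1-n1cnnn1)[C@@H]1[C@H]2C[C@H]2CN1C(=O)[C@H](O)CC1CC1`: compound 1 gives < 14 mL.min-1.g-1, which is a limit of the assay rather than a number.
- compound 2 `CC(C)(C)[C@@H](O)C(=O)N1CC(=O)C[C@H]1C(=O)NCc1cc(Cl)ccc1-n1cnnn1`: compound 2 gives < 12 mL.min-1.g-1, likewise a limit.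
- compound 3 `O=C(NCc1cc(Cl)ccc1-n1cnnn1)[C@@H]1C[C@@H]2C[C@@H]2N1C(=O)[C@H](O)c1cccc(Cl)c1`: compound 3 gives > 500 mL.min-1.g-1, also a limit.

Within the data shown here, none of the three values is a number, so no step between measured compounds can be sized. Compound 1 and compound 2 both sit at a low limit (the limit of < 14 mL.min-1.g-1 in this assay, at which 1 of the 3 values shown sits, (the limit of < 12 mL.min-1.g-1 in this assay, at which 1 of the 3 values shown sits)), while compound 3 sits at the high limit (the limit of > 500 mL.min-1.g-1 in this assay, at which 1 of the 3 values shown sits). Compound 1 therefore stands at the slow-clearance end of what has been seen in this assay, with only an upper bound known.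

Compound 4 `O=C(NCc1cc(Cl)ccc1-n1cnnn1)[C@@H]1[C@H]2C[C@H]2CN1C(=O)[C@H](O)C1CCCCC1` differs from compound 1 in one place: cyclohexyl in place of cyclopropylmethyl on a saturated chain carbon bound to a carbonyl carbon and an oxygen on a saturated carbon. Whether this change moves clearance in this assay is not shown by any measured pair. The expectation is a modest rise in clearance for compound 4, the step of an at least 2.8-fold higher number from compound 1 to compound 4 (0.45 log units; beyond the scatter) being estimated as beyond the scatter but well short of the high limit where compound 3 sits. Compound 4 is expected to give 40 mL.min-1.g-1, within 12 mL.min-1.g-1 to 150 mL.min-1.g-1.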

Compound 4, intrinsic clearance in microsomes: 110 mL.min-1.g-1
Compound 4: middle estimate off by 2.8-fold (0.44 log units), on the low side, and the stated range covers the measured number.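

In this assay, the first pair differing in one place shows that this position bears on clearance: cyclohexyl in place of cyclopropylmethyl, on a saturated chain carbon bound to a carbonyl carbon and an oxygen on a saturated carbon, gives an at least 7.8-fold higher number from compound 1 to compound 4 (0.89 log units; beyond the scatter). On the core of compound 1, this single change is enough to give a read-out that is a number, with compound 4 at 110 mL.min-1.g-1. The step has only a lower bound and no full size because the value for compound 1 is a limit, not a number: the limit of < 14 mL.min-1.g-1 in this assay, at which 1 of the 4 values shown sits.

With a single pair, the compounds shown do not separate the effect of ring size from that of carbon count, and they set no trend at this position. They also leave open how clearance responds here to an amine, a carboxylic acid or a longer chain, and whether the same change would give a similar step on the different cores of compound 2 and compound 3.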